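The source may report more compounds than this note shows. Statements on the series, on what has been measured and on what is new or still open speak of the compounds shown alone.

Compound 1 `CCC1Nc2cccc([C@@H]3C[C@H]3CNC(=O)C(C)C)c2O1` and compound 2 `CCCC1Nc2cccc([C@@H]3C[C@H]3CNC(=O)C(C)C)c2O1` share one core and differ only in a short chain on a saturated ring carbon. In an assay on NIH3T3 cells with melatonin receptor type 1B (Homo sapiens) as the target (on this read-out lower numbers stand for stronger inhibition and higher numbers for weaker inhibition), compound 1 gives 0.75 nM, while compound 2 gives 0.28 nM in this assay. The step of a 2.7-fold lower number from compound 1 to compound 2 (0.43 log units; beyond the scatter) shows that the longer chain brought a clear gain. Of the two numbers seen so far, compound 2 holds the lowest, with compound 1 as its nearest neighbour. Compound 3 `CC(C)C(=O)NC[C@@H]1C[C@H]1c1cccc2c1OC(C(C)C)N2` keeps every atom of compound 2 but joins them differently: isopropyl in place of propyl on a saturated ring carbon. For the measured compounds named here, only the step from compound 1 to compound 2 bears on this change, and it concerned chain length rather than branching, so it is a weak guide; a change within the usual scatter, in either direction, seems most likely. For compound 3 the number in this assay is therefore expected near 0.35 nM, between 0.12 nM and 1 nM. That estimate means a step of a 1.3-fold higher number from compound 2 to compound 3 (0.10 log units; within the scatter), expected to stay within the scatter.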

Compound 3, inhibition constant: 2.5 nM
Beside the measured number, compound 3's estimate is 7.1-fold (0.85 log units) below it, outside the stated range (above it).
By their numbers in this assay, from the lowest: compound 2; then compound 1; then compound 3.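

Replacing propyl with isopropyl on this saturated ring carbon gives an 8.9-fold higher number from compound 2 to compound 3 (0.95 log units; beyond the scatter) in this assay, so the same three carbons, joined differently, give much weaker inhibition. The earlier comparison showed only that the longer straight chain of compound 2 beat the shorter chain of compound 1, whereas the branched chain gives a 3.3-fold higher number from compound 1 to compound 3 (0.52 log units; beyond the scatter) and falls behind even that shorter chain. Nothing available explains why branching at this position has such an effect.

As far as these compounds go, with only three chains to compare, it remains open whether a longer straight chain such as butyl would lower the number further. It is also unclear whether a small ring such as cyclopropyl at this carbon would behave more like propyl or isopropyl.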